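From Ethoxy to Pyrrolidin-1-yl on a Carbonyl Carbon

A few compounds are considered here, and "the series" means these few. Any claim that something is new, unique, unknown or untested is made for them only; others in the source may bear on it.

In a functional assay on K562 cells (Homo sapiens) for cytotoxicity, read by MTT assay, with a stated time of 48 h (a higher number here means a weaker inhibitor, a lower number a stronger inhibitor), compound 1 `CCOC(=O)/C=C/c1ccc2c(c1)C(=O)C(=O)N2Cc1ccc(OC)cc1` gives 10 nM as the lowest of three measured numbers. Compound 3 `COC(=O)/C=C/c1ccc2c(c1)C(=O)C(=O)N2C` gives 340 nM by comparison, and compound 2 `COC(=O)/C=C/c1ccc2c(c1)N(Cc1ccc(OC)cc1)C(=O)C2=O` gives 4860 nM as the highest. No two of these compounds differ in one place only, so none of them shows the next change directly. Compound 4 `COc1ccc(CN2C(=O)C(=O)c3cc(/C=C/C(=O)N4CCCC4)ccc32)cc1` has not been measured and carries pyrrolidin-1-yl in place of ethoxy on a carbonyl carbon within the core of compound 1. Compound 1 at 10 nM has little company at the low end, so a rise is more likely than a fall. The expected step of a 20-fold higher number from compound 1 to compound 4 (1.30 log units; beyond the scatter) points to weaker inhibition. Compound 4 is estimated at 200 nM (25 nM to 2000 nM).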

Compound 4, half-maximal inhibitory concentration: 460 nM
Beside the measured number, compound 4's estimate is 2.3-fold (0.36 log units) below it; the measured number falls inside the stated range.
By their numbers in this assay, from the lowest: compound 1; then compounds 3 and 4 (each within the scatter of the next); then compound 2.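

Going by these compounds alone, this is the first change that can be read on its own: in this assay, pyrrolidin-1-yl in place of ethoxy on a carbonyl carbon gives a 46-fold higher number from compound 1 to compound 4 (1.66 log units; beyond the scatter), a large step. So the group on this carbonyl carbon matters, and this replacement weakens inhibition. Nothing at hand explains the rise.

As far as these compounds go, it remains open whether the loss follows from the ring or from the nitrogen itself. An open-chain diethylamino group on the same carbonyl carbon would separate these two possibilities.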